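A few compounds are considered here, and "the series" means these few. Any claim that something is new, unique, unknown or untested is made for them only; others in the source may bear on it.

- compound 1 `CC/C=C\[C@H](C)[C@H](OC(N)=O)[C@@H](C)[C@H](O)[C@@H](C)C/C(C)=C\[C@H](C)[C@@H](O)[C@@H](C)/C=C\[C@@H](O)C[C@@H]1OC(=O)[C@H](C)C[C@H]1C` gives 5.8 nM in a functional assay on MCF7 cells (Homo sapiens) for antiproliferative activity; on this read-out higher numbers stand for weaker inhibition of growth and lower numbers for stronger inhibition of growth
- compound 2 `CC/C=C\[C@H](C)[C@H](OC(N)=O)[C@@H](C)[C@H](O)[C@@H](C)C/C(C)=C\[C@H](C)[C@@H](O)[C@@H](C)/C=C\[C@@H](O)C[C@@H]1OC(=O)NC[C@H]1C` gives 110 nM in this assay

Going by the values given here, compound 2 holds the higher of these two numbers, so it is the weaker growth inhibitor of the pair, and compound 1 is its only measured neighbour. The next compound, compound 3 `CC/C=C\[C@H](C)[C@H](OC(N)=O)[C@@H](C)[C@H](O)[C@@H](C)C/C(C)=C\[C@H](C)[C@@H](O)[C@@H](C)/C=C\[C@H](O)C[C@@H]1CCC(=O)O1`, differs from compound 2 by a group of 9 heavy atoms (6 carbon, 3 oxygen; one five-membered non-aromatic ring with 1 hetero atom) in place of a group of 11 heavy atoms (7 carbon, 1 nitrogen, 3 oxygen; one six-membered non-aromatic ring with 2 hetero atoms), on a double-bonded chain carbon bound to a double-bonded chain carbon and so swaps the ring-bearing group once more. Among the compounds with values here, one measured step bears on this, and it too was a swap of the ring-bearing group: a 19-fold higher number from compound 1 to compound 2 (1.28 log units; beyond the scatter), which is large. Within the data shown here, no measured compound carries a five-membered ring, so the size of the new step is uncertain. A further rise is expected, with the estimate meaning a 3.2-fold higher number from compound 2 to compound 3 (0.50 log units; beyond the scatter) in this assay. For compound 3 the estimated value is 350 nM, within an expected range of 80 nM to 1500 nM.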

Compound 3, concentration for 50% growth inhibition: 2000 nM
Compound 3: middle estimate off by 5.7-fold (0.76 log units), on the low side; the whole stated range lies below it.
By their numbers in this assay, from the lowest: compound 1; then compound 2; then compound 3.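

Moving to the five-membered non-aromatic ring with 1 hetero atom is a second large loss of growth inhibition in this assay, with an 18-fold higher number from compound 2 to compound 3 (1.26 log units; beyond the scatter). Over the two swaps the change reaches a 340-fold higher number from compound 1 to compound 3 (2.54 log units; beyond the scatter), which leaves compound 1 the strongest and compound 3 the weakest growth inhibitor of the three, so the activity of this series depends strongly on the ring-bearing group at this position. No measurement at hand accounts for the loss.

Compound 3 changes the ring size, the ring atoms and the defined stereocentres in a single step, so the compounds shown cannot say which of these carries the drop. As far as these compounds go, it also remains open how a five-membered ring carrying a methyl group, or a six-membered ring with no methyl group, would behave in this assay.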